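From thione to amine on a saturated ring carbon

A few compounds are considered here, and "the series" means these few. Any claim that something is new, unique, unknown or untested is made for them only; others in the source may bear on it.

Compound 2 `S=c1[nH]nc(C2CCN(c3nc(-c4ccccc4)nc4ccccc34)CC2)s1` is one of two compounds tested in a functional assay on the whole organism for inhibition, with Rattus norvegicus as the target, read by paw edema, with stated times of 4 days, 1 h and 2 h, at a dose of 100 mg/kg by the oral route; on this read-out lower numbers stand for less inhibition and higher numbers for more inhibition at the one dose given (going by the name of the read-out). In this assay compound 2 gives 71.3%, the lower of the two numbers, while compound 1 `c1ccc(-c2nc(N3CCC(c4ccccc4)CC3)c3ccccc3n2)cc1` gives 85.3%. Within the data shown here, the one measured step, a number 14 percentage points lower from compound 1 to compound 2 (beyond the scatter), concerns a change of a different kind, a six-membered aromatic ring of carbon only replaced by a five-membered aromatic ring with three hetero atoms. Compound 3 `Nc1nnc(C2CCN(c3nc(-c4ccccc4)nc4ccccc34)CC2)s1` differs from compound 2 by a group of 6 heavy atoms (2 carbon, 3 nitrogen, 1 sulfur; one five-membered aromatic ring with 3 hetero atoms) in place of a group of 6 heavy atoms (2 carbon, 2 nitrogen, 2 sulfur; one five-membered aromatic ring with 3 hetero atoms), on a saturated ring carbon. Among the measured compounds shown here, no measured step bears directly on this exchange of one five-membered aromatic ring with three hetero atoms for another on the same saturated ring carbon; the single known step shows only that a change at this carbon can move the read-out by a modest amount. With nothing pointing in either direction, compound 3 is expected to stay close to compound 2, a step of a number 1.3 percentage points lower from compound 2 to compound 3 (within the scatter) within the scatter. The estimate for compound 3 in this assay is 70%, with a range from 55% to 85%.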

Compound 3, a percentage reported as inhibition, in the whole organism at one dose (the size of the read-out at that dose, not a potency): 73%
The estimate for compound 3 lay 3 percentage points below the measured number; the range from low to high includes it.
By their numbers in this assay, from the lowest: compounds 2 and 3 (each within the scatter of the next); then compound 1.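

In this assay, putting 5-amino-1,3,4-thiadiazol-2-yl on the saturated ring carbon in place of the group carried by compound 2 gives a number 1.7 percentage points higher from compound 2 to compound 3 (within the scatter), so this read-out does not separate these two five-membered aromatic rings. Measured against phenyl, the same change gives a number 12.3 percentage points lower from compound 1 to compound 3 (beyond the scatter), which places compound 3 with compound 2 on the lower side of compound 1 and shows that the gap from phenyl is not confined to a single five-membered ring. Nothing measured here offers an explanation for either step.

The compounds shown leave open whether a group without a ring at this carbon, such as a simple amine or a carboxylic acid, would read nearer to compound 1 or to compounds 2 and 3. They also leave open whether a phenyl carrying a chlorine would keep the number of compound 1.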